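Swapping a bromophenyl for an indole on a sulfonyl enone

The source may hold more compounds than are shown below. What is called first, only, known or untested is meant among the compounds shown, and "the series" means these compounds.

Measured compounds:
Compound 1, `Cc1ccc(S/C(=C/c2c[nH]c3ccccc23)C(=O)c2ccc(Br)cc2)cc1`: 10000 nM
Compound 2, `O=C(/C(=C\c1ccc(Br)cc1)S(=O)(=O)c1ccc(Br)cc1)c1ccc(Br)cc1`: 10000 nM

Both compounds were tested in a functional assay on DU-145 cells (Homo sapiens) for inhibition, read by trypan blue exclusion, with a stated time of 96 h; a lower number here means a stronger inhibitor of growth, a higher number a weaker inhibitor of growth. Compound 1 gives 10000 nM in this assay. Compound 2 gives 10000 nM, and on the digits shown it stands level with compound 1, within the scatter of the measurement, so nothing separates the two in this assay.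

The step of interest leads from compound 2 to compound 3, `O=C(/C(=C\c1c[nH]c2ccccc12)S(=O)(=O)c1ccc(Br)cc1)c1ccc(Br)cc1`. The change is 1H-indol-3-yl in place of 4-bromophenyl on a double-bonded chain carbon bound to a double-bonded chain carbon. Compound 1 already carries the same indol-3-yl group on the same chain carbon, with a different sulfur linkage, and its value of 10000 nM is no different from that of compound 2. Among the compounds with values here, no step between measured compounds is available to show what this exchange does on its own, so the expectation rests on those two values alone.

From compound 2 to compound 3 the step expected in this assay is no change at the digits printed from compound 2 to compound 3 (within the scatter), that is, none beyond the scatter. Compound 3 is therefore estimated at 10000 nM, with a range from 3000 nM to 30000 nM.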

Compound 3, concentration for 50% growth inhibition: 25000 nM
Compound 3: middle estimate off by 2.5-fold (0.40 log units), on the low side; low and high end bracket the measured number.
By their numbers in this assay, from the lowest: compounds 1 and 2 (each within the scatter of the next); then compound 3.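

In this assay, 1H-indol-3-yl in place of 4-bromophenyl on a double-bonded chain carbon bound to a double-bonded chain carbon gives a 2.5-fold higher number from compound 2 to compound 3 (0.40 log units; beyond the scatter), so this exchange does register at this position, and it moves towards weaker inhibition of growth rather than stronger. With the indole kept, (4-bromophenyl)sulfonyl in place of (4-methylphenyl)sulfanyl gives a 2.5-fold higher number from compound 1 to compound 3 (0.40 log units; beyond the scatter), which shows that the sulfur linkage also matters in this series and leaves compound 3 as the weakest inhibitor of the three. Nothing at hand explains either step.

Within the data shown here, the indole exchange is seen only with the (4-bromophenyl)sulfonyl group in place, so whether it would give a similar step with the (4-methylphenyl)sulfanyl group remains open. Also open, on these data alone, is whether a different group on the same chain carbon, such as a 4-aminophenyl or a 4-carboxyphenyl, would bring the number down rather than up.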